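This account rests on a few compounds, and the source may have more. Where it says the series, first, only, none or still open, it means among the compounds named here.

Four amides on one shared core, with a nitro or a trifluoromethyl group on the anilide ring, measured for solubility.

Compound 1 `O=C(Nc1ccc([N+](=O)[O-])cc1)c1cc(Cl)ccc1O` carries the nitro group; in a physicochemical assay for solubility (on this read-out higher numbers stand for higher solubility and lower numbers for lower solubility), compound 1 gives 6.4 ug/mL. Compound 2 `O=C(Nc1ccc(C(F)(F)F)cc1)c1cc(Cl)ccc1O` carries trifluoromethyl at the same place. For compound 2 the value of < 1 ug/mL in this assay is a limit of the assay and not a number. The change nitro in place of trifluoromethyl on an aromatic carbon produced the step of an at least 6.4-fold higher number from compound 2 to compound 1 (0.80 log units; beyond the scatter); its size is open at one end because compound 2 sits at the limit of < 1 ug/mL in this assay, at which 1 of the 3 values shown sits.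

Compound 3 `O=C(Nc1ccccc1C(F)(F)F)c1cc(Cl)ccc1O` has the same atoms as compound 2, joined differently; the difference between the two cores is not broken down here. For compound 3 the value of > 47 ug/mL in this assay is a limit of the assay and not a number, so compound 3 stands at the limit of > 47 ug/mL in this assay, at which 1 of the 3 values shown sits.

Compound 4 `O=C(Nc1ccccc1[N+](=O)[O-])c1cc(Cl)ccc1O` is not yet measured. The change from compound 3 is nitro in place of trifluoromethyl on an aromatic carbon. It is the same kind of change as from compound 2 to compound 1, but the surroundings differ: para to a large group in the measured pair, ortho to a large group here. Since compound 3 already reads as a limit and the measured step of an at least 6.4-fold higher number from compound 2 to compound 1 (0.80 log units; beyond the scatter) rose, the step that the limit leaves unreadable from compound 3 to compound 4 is expected to be small or upward, and compound 4 is expected to report again as a limit or close to it. The estimate for compound 4 is 60 ug/mL, expected between 20 ug/mL and 150 ug/mL.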

Compound 4, solubility: 15.4 ug/mL
For compound 4 the middle estimate is 3.9-fold (0.59 log units) above the measured one; measured number below the stated range.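

Nitro in place of trifluoromethyl does not carry its direction from one core to the other: in this assay the change gives an at least 6.4-fold higher number from compound 2 to compound 1 (0.80 log units; beyond the scatter), whereas with the group ortho to a large group it gives an at least 3.0-fold lower number from compound 3 to compound 4 (0.48 log units; beyond the scatter), and both steps lie beyond the scatter, so the sign of this change cannot be transferred between these two pairs, while the data give no reason for the reversal and two pairs establish no rule for the series. The first step is open at one end, and its full size cannot be read, as compound 2 stands at a limit of the assay and not a number: the limit of < 1 ug/mL in this assay, at which 1 of the 4 values shown sits. The second step is likewise only a minimum, as compound 3 stands at a limit of the assay and not a number: the limit of > 47 ug/mL in this assay, at which 1 of the 4 values shown sits.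

The compounds shown carry only nitro and trifluoromethyl on the anilide ring, so how an amine, a carboxylic acid or a longer chain would read there stays open. Also open, as far as these compounds go, are the true sizes of both steps and whether the opposite directions would persist if the chloro or hydroxy group of the shared core were replaced.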